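The source may report more compounds than this note shows. Statements on the series, on what has been measured and on what is new or still open speak of the compounds shown alone.

In an ADME assay on a cell-free system (plasma, Rattus norvegicus) for metabolic stability, read by LC-MS, with a stated time of 1 h, at 37 degrees C, tested at 100 uM (on this read-out higher numbers stand for a more stable compound and lower numbers for a less stable compound), the evidence so far is thin. Within the data shown here, compound 1 (`O=C(O)c1cc(-c2cccc(COc3ccc4c(=O)n(CC5CC5)sc4c3)c2)ccc1Cl`) gives 100%, the only number available, so it cannot be placed against any other result. Compound 2 (`O=C1c2ccc(OCc3cccc(-c4ccc(C(F)(F)F)cc4F)c3)cc2CN1C1CCCC1`) offers no comparison, as its entry reads "not determined" (no result reported).

Compound 3 (`CC(C)Cn1sc2cc(OCc3cccc(-c4ccc(Cl)c(C(=O)O)c4)c3)ccc2c1=O`) has not yet been measured. It keeps the core of compound 1 and differs in one place: isopropyl in place of cyclopropyl on a saturated chain carbon bound to an aromatic nitrogen. In words, isopropyl stands in place of cyclopropyl on a saturated chain carbon bound to an aromatic nitrogen. Cut one bond further out, the same difference reads cyclopropylmethyl to isobutyl.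

Among the measured compounds shown here, no measured pair shows what this change does, so the expectation rests on compound 1 alone. No step beyond the usual scatter is expected in this assay. Any small shift would more likely be downward because compound 1 stands at 100%. The estimated change is a number 4 percentage points lower from compound 1 to compound 3 (within the scatter), which stays within that scatter. For compound 3 the expected value is 96%, with an estimated range from 84% to 103%.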

Compound 3, percent of the compound remaining: 95%
Estimate against measurement, compound 3: 1 percentage points above, and the stated range covers the measured number.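

In this assay, among these compounds, the change from cyclopropyl to isopropyl on a saturated chain carbon bound to an aromatic nitrogen gives a number 5 percentage points lower from compound 1 to compound 3 (within the scatter), the first reading of any change at this position. The three-membered ring is gone and the count of 3 heavy atoms is kept, yet the read-out does not separate the two compounds, so for this one pair the closed ring and the open branched group cannot be told apart. Nothing available explains this result or links it to any property of either group.

Among the compounds shown here, the single pair says nothing about a group at this place that differs more from cyclopropylmethyl and isobutyl, such as a longer chain like n-hexyl or a chain ending in a primary amine. It also leaves open how this assay would read with a methyl ester in place of the carboxylic acid that compound 1 and compound 3 share, since no change away from that group appears among the compounds shown.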